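Removing both hydroxyls of compound 2 to reach compound 4

The compounds below may be only part of what the source reports. "The series", "measured", "known", "first", "only" and "open" are said of these compounds alone.

Three members of the series have been measured in a functional assay on HT-29 cells (Homo sapiens) for cytotoxicity, read by MTT assay, with a stated time of 72 h; a lower number here means a stronger inhibitor, a higher number a weaker inhibitor. Compound 1 `CN(C)CCn1cnnc1-c1cc(Oc2ccc(NC(=O)N/N=C/c3ccc(F)cc3Cl)cc2F)ccn1` gives 510 nM. Compound 2 `CN(C)CCn1cnnc1-c1cc(Oc2ccc(NC(=O)N/N=C/c3ccc(O)c(O)c3)cc2F)ccn1` gives 1890 nM. Compound 3 `CN(C)CCn1cnnc1-c1cc(Oc2ccc(NC(=O)N/N=C/c3ccc(O)c(Br)c3)cc2F)ccn1` gives 450 nM. Compound 2 thus has the highest number of the three: a 3.7-fold higher number from compound 1 to compound 2 (0.57 log units; beyond the scatter), and a 4.2-fold lower number from compound 2 to compound 3 (0.62 log units; beyond the scatter). The other pair, compound 1 and compound 3, differ only within the scatter: a 1.1-fold lower number from compound 1 to compound 3 (0.05 log units; within the scatter).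

Compound 4 `CN(C)CCn1cnnc1-c1cc(Oc2ccc(NC(=O)N/N=C/c3ccccc3)cc2F)ccn1` has not been measured. Against compound 2 the change is phenyl in place of 3,4-dihydroxyphenyl on a carbon with a double bond to nitrogen.

Within the data shown here, two measured steps bear on it, since both remove hydroxy from the aryl group on the carbon with a double bond to nitrogen. First, the reverse of a 3.7-fold higher number from compound 1 to compound 2 (0.57 log units; beyond the scatter): an aryl without hydroxy gives the lower number. Second, a 4.2-fold lower number from compound 2 to compound 3 (0.62 log units; beyond the scatter): trading one hydroxy for bromo lowers the number by a similar margin. Neither step is a plain phenyl, so the size is uncertain, but the direction is consistent.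

The expected step is therefore a decrease beyond the scatter, of a size like those two: a 3.4-fold lower number from compound 2 to compound 4 (0.54 log units; beyond the scatter). Compound 4 is estimated at 550 nM in this assay, with a range from 250 nM to 1300 nM.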

Compound 4, half-maximal inhibitory concentration: 1120 nM
Compound 4: the middle estimate sits 2.0-fold (0.31 log units) below what was measured; the range from low to high includes it.
By their numbers in this assay, from the lowest: compounds 3 and 1 (each within the scatter of the next); then compounds 4 and 2 (each within the scatter of the next).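

In this assay, the plain phenyl of compound 4 cannot be told apart from the 3,4-dihydroxyphenyl of compound 2 (a 1.7-fold lower number from compound 2 to compound 4 (0.23 log units; within the scatter)), so removing both hydroxy groups at this carbon brings no step beyond the scatter. The earlier gaps therefore read differently: they no longer mark hydroxy as a penalty, since the halogen-bearing aryl groups also stand apart from plain phenyl (a 2.5-fold higher number from compound 3 to compound 4 (0.40 log units; beyond the scatter); a 2.2-fold higher number from compound 1 to compound 4 (0.34 log units; beyond the scatter)), and among these four compounds only compounds 1 and 3 stand beyond the scatter from the unsubstituted ring. No measurement shown here accounts for these differences.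

Compounds 1 and 3 differ in their halogens and in the presence of hydroxy, so it remains open whether a single bromo, chloro or fluoro on the phenyl is enough to reproduce their values, or whether the combinations shown are needed. It is also open how this carbon tolerates aryl groups carrying a methoxy, an amino group or a carboxylic acid, none of which appears among these compounds.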